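The compounds below may be only part of what the source reports. "The series", "measured", "known", "first", "only" and "open" are said of these compounds alone.

Compound 1 `O=S(=O)(Nc1ccc(-c2nc3ccccc3o2)cc1)c1cccc(F)c1` is a sulfonamide tested in an assay on isolated protein for inhibition of malate dehydrogenase, mitochondrial (Sus scrofa), with stated times of 45 min and 30 min; a lower number here means a stronger inhibitor, a higher number a weaker inhibitor. In this assay compound 1 gives > 63000 nM, which is a limit of the assay rather than a measured number. Compound 2 `O=S(=O)(Nc1ccc2oc(-c3ccccc3)nc2c1)c1cccc(C(F)(F)F)c1` gives > 63000 nM in this assay, again only a limit. Compound 3 `Cc1ccc(S(=O)(=O)Nc2ccc3oc(-c4ccccc4)nc3c2)cc1` likewise gives > 63000 nM in this assay, also a limit. The whole picture is summed up by the limit of > 63000 nM in this assay, at which 3 of the 3 values shown sit, so compound 1 stands level with the other two and none of the three can be ranked against another.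

Compound 4 `O=S(=O)(Nc1ccc(-c2nc3ccccc3o2)cc1)c1ccc(Cl)s1` is the compound still to be measured. It differs from compound 1 by 5-chlorothiophen-2-yl in place of 3-fluorophenyl on a sulfonyl sulfur, in words 5-chlorothiophen-2-yl in place of 3-fluorophenyl on a sulfonyl sulfur. Going by the values given here, no pair of measured compounds differing in a single place is available, so there is no measured step to lean on. Because compound 1 gives only the limit > 63000 nM, the expected step is a step that the limit leaves unreadable from compound 1 to compound 4, which means no change beyond the scatter. Compound 4 is therefore expected to give about 100000 nM, within a range from 30000 nM to 300000 nM, most probably again as a limit.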

Compound 4, half-maximal inhibitory concentration: > 63000 nM
Compound 4: no number, only a limit; the forecaster's own chance of this, stated with the estimate: 85%; the middle value does not contradict the limit.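

Going by these compounds alone, compound 4 gives > 63000 nM in this assay, which is again a limit and not a number, so no step between compound 1 and compound 4 can be read: the limit of > 63000 nM in this assay, at which 4 of the 4 values shown sit. The compounds shown leave open how strongly any of them inhibits this enzyme.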